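A few compounds are considered here, and "the series" means these few. Any claim that something is new, unique, unknown or untested is made for them only; others in the source may bear on it.

The set comprises four compounds built on a shared core: compound 1 `O=C(Nc1ccccc1)c1c(NO)cc(-c2ccc(Cl)cc2)oc1=O`, compound 2 `COc1ccc(-c2cc(NO)c(C(=O)Nc3ccccc3)c(=O)o2)cc1`, compound 3 `O=C(Nc1ccc(F)cc1)c1c(NO)cc(-c2ccccc2)oc1=O` and the not yet measured compound 4 `Cc1cccc(NC(=O)c2c(NO)cc(-c3ccccc3)oc2=O)c1`. In an ADME assay on Huh-7 cells (Homo sapiens) for cytotoxicity, read by a luciferase reporter and WST assay, with a stated time of 3 days (a lower number here means that less compound is tolerated, a higher number that more compound is tolerated), compound 1 gives 11000 nM. Compound 2 gives 16200 nM in this assay, and the step of a 1.5-fold higher number from compound 1 to compound 2 (0.17 log units; within the scatter) stays within the scatter. Compound 3 gives only a limit in this assay, namely > 20000 nM. Compound 3 thus stands at the limit of > 20000 nM in this assay, at which 1 of the 3 values shown sits, and no number is available for it. Compound 4 differs from compound 3 by 3-methylphenyl in place of 4-fluorophenyl on an amide-type nitrogen. Going by the values given here, none of the measured steps alters the group on the amide nitrogen, so no measured step bears directly on this change; the single measured step, a 1.5-fold higher number from compound 1 to compound 2 (0.17 log units; within the scatter), concerns a different part of the molecule and was within the scatter. With compound 3 sitting at a limit, compound 4 is expected to be tolerated similarly, and the step of a number no higher from compound 3 to compound 4 (the limit leaves the size open) is expected to remain within the scatter. Compound 4 is therefore estimated at 20000 nM in this assay, with a range from 9000 nM to 45000 nM.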

Compound 4, half-maximal cytotoxic concentration: > 20000 nM
Compound 4: only a limit was reported; the forecaster's own chance of this, stated with the estimate: 50%; the middle value lies on the limit itself.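

No new step can be read between compound 3 and compound 4 in this assay, since each of them stands at a limit and not at a number: the limit of > 20000 nM in this assay, at which 2 of the 4 values shown sit. The compounds shown leave open how much compound either one tolerates beyond that limit, and whether 3-methylphenyl in place of 4-fluorophenyl on an amide-type nitrogen changes the result at all.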